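A Dichlorophenyl Exchange in a Narrow Cytotoxicity Series

A few compounds are considered here, and "the series" means these few. Any claim that something is new, unique, unknown or untested is made for them only; others in the source may bear on it.

In a functional assay on MCF7 cells (Homo sapiens) for cytotoxicity, read by MTT assay, with a stated time of 72 h (on this read-out lower numbers stand for stronger inhibition and higher numbers for weaker inhibition), three compounds on a shared core have been measured so far. Compound 1 (`COc1cccc(/C=C2\CCC/C(=C\c3ccccc3Cl)C2=O)c1OC`) stands at 11300 nM and compound 2 (`COc1cccc(/C=C2\CCC/C(=C\c3cccc(Br)c3)C2=O)c1OC`) at 11700 nM while compound 3 (`COc1ccc(/C=C2\CCC/C(=C\c3cccc(OC)c3OC)C2=O)cc1`) reads 18600 nM on the same scale. All three numbers lie within the scatter of one another, so compound 3 cannot be told apart from either of the others.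

Compound 4 (`COc1cccc(/C=C2\CCC/C(=C\c3ccc(Cl)cc3Cl)C2=O)c1OC`) departs from compound 3 in one place, with 2,4-dichlorophenyl in place of 4-methoxyphenyl on a double-bonded chain carbon bound to a double-bonded ring carbon. Within the data shown here, no measured compound carries this entering group. The closest evidence is two steps at the same place that end at 4-methoxyphenyl, namely a 1.6-fold higher number from compound 1 to compound 3 (0.22 log units; within the scatter) from 2-chlorophenyl and a 1.6-fold higher number from compound 2 to compound 3 (0.20 log units; within the scatter) from 3-bromophenyl. The step between those two groups, a 1.0-fold higher number from compound 1 to compound 2 (0.02 log units; within the scatter) as well, is just as small. Read backwards, the first two steps point weakly towards a lower number once 4-methoxyphenyl leaves.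

The estimated change is a 1.6-fold lower number from compound 3 to compound 4 (0.19 log units; within the scatter) and so no shift beyond the scatter is expected. Compound 4 is expected to read about 12000 nM in this assay with an estimated range from 5500 nM to 24000 nM around that figure.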

Compound 4, half-maximal inhibitory concentration: > 20000 nM
Compound 4 gave a limit, no number (the forecaster's own chance of this, stated with the estimate: 3%); middle value at least 1.6-fold (0.22 log units) from the limit.
By their numbers in this assay, from the lowest: compounds 1, 2 and 3 (each within the scatter of the next). At a limit, above all of these: compound 4.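

In this assay compound 4 gives a limit of the assay and not a number: the limit of > 20000 nM in this assay, at which 1 of the 4 values shown sits. Its three steps can be read only as floors, and each floor lies within the scatter: for the exchange of 4-methoxyphenyl (an at least 1.0-fold higher number from compound 3 to compound 4 (0.03 log units; that floor lies within the scatter)), for the exchange of 3-bromophenyl (an at least 1.7-fold higher number from compound 2 to compound 4 (0.23 log units; that floor lies within the scatter)), and for chloro in place of hydrogen on an aromatic carbon (an at least 1.7-fold higher number from compound 1 to compound 4 (0.24 log units; that floor lies within the scatter)). Among these compounds, what the earlier compounds did not show is that a change on this double-bonded chain carbon bound to a double-bonded ring carbon can reach the limit of the read-out, where 2-chlorophenyl, 3-bromophenyl and 4-methoxyphenyl all gave numbers, although these floors do not yet set compound 4 apart from compounds 1, 2 and 3.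

From the compounds shown here alone, how far compound 4 lies past its limit remains open, and so does whether its true steps exceed the scatter. Also open is whether a phenyl carrying an amine or a carboxylic acid at this place would read differently from the groups shown here.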